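A few compounds are considered here, and "the series" means these few. Any claim that something is new, unique, unknown or untested is made for them only; others in the source may bear on it.

Working notes on the series. Compound 1 `c1cc(CC2CCCCC2)nc(N2CCNCC2)c1` gives 100 mg/kg in a functional assay on the whole organism with Mus musculus as the target, in the maximal electroshock model, with a stated time of 120 min; on this read-out higher numbers stand for an effect only at larger amounts of compound and lower numbers for an effect already at smaller amounts. Compound 2 `CCCCCCCCc1cccc(N2CCNCC2)n1` gives 10 mg/kg, and compound 3 `CCCCCCCc1cccc(N2CCNCC2)n1` gives 10 mg/kg. Compound 3 thus stands level with compound 2 at the digits recorded, the two together at the lowest of the three numbers, with compound 1 the furthest away from it. Going by the values given here, the step between them, a 10-fold lower number from compound 1 to compound 3 (1.00 log units; beyond the scatter), is the only change of size seen so far; the other step, no change at the digits printed from compound 2 to compound 3 (within the scatter), stays within the scatter.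

Compound 4 `CCCCCCc1cccc(N2CCNCC2)n1` has not yet been measured. It differs from compound 3 by hydrogen in place of methyl on a saturated chain carbon, six bonds along the chain from an aromatic carbon. The step from compound 2 to compound 3, which removes a methyl one bond further out along the same chain, bears most directly on this change, and it produced no shift beyond the scatter. On that single precedent, no step beyond the scatter is expected in this assay, so that the expected step is no change at the digits printed from compound 3 to compound 4 (within the scatter). The estimate for compound 4 is therefore 10 mg/kg, with a range from 5 mg/kg to 30 mg/kg.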

Compound 4, minimum effective dose: 10 mg/kg
Estimate against measurement, compound 4: no gap at the digits printed; the range from low to high includes it.
By their numbers in this assay, from the lowest: compounds 2, 3 and 4 (each within the scatter of the next); then compound 1.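

In this assay, going by these compounds alone, hydrogen in place of methyl, six bonds along the chain from an aromatic carbon, gives no change at the digits printed from compound 3 to compound 4 (within the scatter) and hydrogen in place of ethyl at the same place gives no change at the digits printed from compound 2 to compound 4 (within the scatter), so the flat stretch of the chain now reaches further in towards the core than the earlier compounds showed. Going from the cyclohexyl group to the straight chain gives a 10-fold lower number from compound 1 to compound 4 (1.00 log units; beyond the scatter), so the gap to compound 1 remains with the shorter straight chain of compound 4. Nothing available explains why the number holds along these chains.

On these data alone, whether a shorter chain such as propyl or ethyl stays level with compound 4, or a longer chain than that of compound 2 stays level with it, remains open. As far as these compounds go, how a terminal amine or carboxylic acid on the chain would read in this assay also remains open.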